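Swapping a Nitro for an Iodine on the Urea Aryl

The source may report more compounds than this note shows. Statements on the series, on what has been measured and on what is new or still open speak of the compounds shown alone.

The measurements come from a functional assay on CRL2813 cells (Homo sapiens) for cytotoxicity, read by sulforhodamine B assay, with a stated time of 5 days; a higher number here means a weaker inhibitor, a lower number a stronger inhibitor. Of the compounds shown here, three have numbers so far. Compound 1 `O=C(Nc1cccc(C(F)(F)F)c1)N[C@H]1CC[C@H](Oc2cccc(C(F)(F)F)c2)CC1` gives 1300 nM in this assay. Compound 3 `O=C(Nc1ccc([N+](=O)[O-])cc1)N[C@H]1CC[C@H](Oc2ccc(F)cc2)CC1` gives 2300 nM in this assay, and this number and that of compound 1 lie within the usual scatter of one another, so the two cannot be told apart. Compound 2 `O=C(Nc1ccccc1C(=O)O)N[C@H]1CC[C@@H](Oc2ccc(F)cc2)CC1` gives only a limit of > 20000 nM in this assay, not a number, which is the limit described by the limit of > 20000 nM in this assay, at which 1 of the 3 values shown sits.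

Compound 4 `O=C(Nc1cccc(I)c1)N[C@H]1CC[C@H](Oc2ccc(F)cc2)CC1` is not yet measured. Compared with compound 3 its change is 3-iodophenyl in place of 4-nitrophenyl on an amide-type nitrogen; the rest of the molecule, the shared core with the 4-fluorophenyl ether, stays the same. Going by the values given here, no measured pair in this set differs in one place, so there is no directly comparable step to lean on, and the effect of this exchange has to be estimated. The expectation is a step from compound 3 to compound 4 of a 1.5-fold lower number from compound 3 to compound 4 (0.19 log units; within the scatter), that is, little movement beyond the scatter, with a slight lean toward a lower number. Compound 4 is therefore expected to give about 1500 nM in this assay, most likely between 500 nM and 5000 nM.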

Compound 4, half-maximal inhibitory concentration: 5200 nM
Estimate against measurement, compound 4: 3.5-fold (0.54 log units) below; measured number outside the range, above it.
By their numbers in this assay, from the lowest: compounds 1 and 3 (each within the scatter of the next); then compound 4. At a limit, above all of these: compound 2.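

Going by these compounds alone, exchanging the group on the amide-type nitrogen gives the first single-place comparison in this set, and in this assay the result is a 2.3-fold higher number from compound 3 to compound 4 (0.35 log units; beyond the scatter). This shows that the position responds to what sits on it: with the 4-fluorophenyl ether and the rest of the shared core unchanged, compound 4 with its 3-iodophenyl is a modestly weaker inhibitor than compound 3 with its 4-nitrophenyl, and the difference is larger than repeat measurements would normally produce. Nothing measured in this set speaks to the reason for this rise.

The exchange replaces the nitro group with an iodine and also changes the substituent's place on the ring, so the compounds shown leave open whether the rise follows the iodine, its place, or the loss of the nitro group. On these data alone, how this position would respond to a different kind of substituent, such as an amine or a nitrile on the same aromatic ring with the rest of compound 3 kept intact, also remains open.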